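Working notes: from compound 3 to compound 4

A few compounds are considered here, and "the series" means these few. Any claim that something is new, unique, unknown or untested is made for them only; others in the source may bear on it.

compound 1 `O=C(CCc1cccc2c1B(O)OC2)Nc1cccc(-c2cccc(F)c2)c1`: 570 nM
compound 2 `O=C(CCc1cccc2c1B(O)OC2)Nc1cccc(-c2ccc(Cl)cc2)c1`: 260 nM
compound 3 `CSc1cccc(-c2cccc(NC(=O)CCc3cccc4c3B(O)OC4)c2)c1`: 150 nM

These values come from a functional assay on MDA-MB-231 cells (Homo sapiens) for antiproliferative activity, read by MTT assay, with a stated time of 72 h; a lower number here means a stronger inhibitor, a higher number a weaker inhibitor. Compound 3 cannot be separated from compound 2, a 1.7-fold lower number from compound 2 to compound 3 (0.24 log units; within the scatter), but stands clearly apart from compound 1, a 3.8-fold lower number from compound 1 to compound 3 (0.58 log units; beyond the scatter). Compound 4 `N#Cc1cccc(-c2cccc(NC(=O)CCc3cccc4c3B(O)OC4)c2)c1` has cyano in place of methylsulfanyl on an aromatic carbon, (cyano in place of methylsulfanyl on an aromatic carbon). The closest measured step also involves methylsulfanyl, which replaces fluoro in going to compound 3, a 3.8-fold lower number from compound 1 to compound 3 (0.58 log units; beyond the scatter). The other step beyond the scatter, a 2.2-fold lower number from compound 1 to compound 2 (0.34 log units; beyond the scatter), is also modest. Within the data shown here, no cyano compound has been measured, so a modest rise is expected, a 2.1-fold higher number from compound 3 to compound 4 (0.33 log units; beyond the scatter). The estimated value for compound 4 is 320 nM, with an expected range of 110 nM to 900 nM.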

Compound 4, half-maximal inhibitory concentration: 110 nM
Estimate against measurement, compound 4: 2.9-fold (0.46 log units) above; low and high end bracket the measured number.
By their numbers in this assay, from the lowest: compounds 4, 3 and 2 (each within the scatter of the next, the first and the last beyond it); then compound 1.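

Cyano and methylsulfanyl cannot be told apart on this aromatic carbon (a 1.4-fold lower number from compound 3 to compound 4 (0.13 log units; within the scatter)), so the sulfur atom is not needed to hold the activity of compound 3. Unlike compound 3, compound 4 separates from the 4-chlorophenyl compound (a 2.4-fold lower number from compound 2 to compound 4 (0.37 log units; beyond the scatter)), and it also lies well clear of the fluoro compound (a 5.2-fold lower number from compound 1 to compound 4 (0.71 log units; beyond the scatter)). No measurement accounts for these differences.

From the compounds shown here alone, whether an amine or a carboxylic acid on the same carbon would match cyano remains open. So does whether cyano would hold its activity at the ring position carrying chloro in compound 2.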